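A few compounds are considered here, and "the series" means these few. Any claim that something is new, unique, unknown or untested is made for them only; others in the source may bear on it.

Going by the values given here, in a functional assay on MCF7 cells (Homo sapiens) for inhibition, read by MTT assay, with a stated time of 72 h, tested at 30 uM (a lower number here means less inhibition of growth, a higher number more inhibition of growth at the concentration tested), only two compounds have numbers so far. Compound 1, `C=CCc1cc(O)c(O)c(CN2CCC(C)CC2)c1`, gives 41.7% in this test, and compound 2, `C=CCc1ccc(OCc2cn(-c3ccc(OC)cc3)nn2)c(O)c1`, gives 38.8% under the same conditions. These two numbers lie within the scatter of each other, so compound 1 cannot be told apart from compound 2 on this evidence.

The next compound to be read is compound 3, `C=CCc1cc(O)c(O)c(CN2CCC(CO)CC2)c1`, which differs from compound 1 in one place: hydroxy in place of hydrogen on a saturated chain carbon bound to a saturated ring carbon. This is hydroxy in place of hydrogen on a saturated chain carbon bound to a saturated ring carbon, so methyl becomes hydroxymethyl.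

Among the compounds with values here, no measured pair shows this change, and the data give no step to scale it by. In this assay the expectation is therefore a small downward move, quite possibly none beyond the scatter. The expected shift is a number 4.7 percentage points lower from compound 1 to compound 3 (within the scatter) as a working figure, held loosely. Compound 3 is estimated at 37% with an expected range from 22% to 52% for this reading.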

Compound 3, percent growth inhibition at one concentration: 26.2%
Compound 3: middle estimate off by 10.8 percentage points, on the high side; low and high end bracket the measured number.
By their numbers in this assay, from the lowest: compound 3; then compounds 2 and 1 (each within the scatter of the next).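

Hydroxy in place of hydrogen on a saturated chain carbon bound to a saturated ring carbon, which turns methyl into hydroxymethyl, gives the first step in the series between compounds that differ in one place: in this assay the reading is a number 15.5 percentage points lower from compound 1 to compound 3 (beyond the scatter). This position is therefore not indifferent to change, since one added oxygen atom, bringing one hydrogen-bond donor and one hydrogen-bond acceptor, is enough to move the reading beyond the scatter and toward less inhibition of growth at the concentration tested. Nothing in the available data accounts for the drop.

This single pair cannot show whether the lower reading belongs to the hydroxy group specifically or would follow from other replacements of methyl at this place, and it cannot show whether the same change would have a similar effect on another core. Methoxymethyl, aminomethyl, a carboxylic acid or a longer chain such as hydroxyethyl at the same place would separate these readings, and the direction of each step remains open.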